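Swapping tert-butyl for cyano on a sulfonamide scaffold

This account rests on a few compounds, and the source may have more. Where it says the series, first, only, none or still open, it means among the compounds named here.

Compound 1, `COc1ccccc1-c1cccc(S(=O)(=O)N2CCC(N3CCC(C)CC3)CC2)c1`, in an ADME assay on HCT-116 cells (Homo sapiens) for cytotoxicity, read by CellTiter-Glo, with a stated time of 72 h (on this read-out lower numbers stand for stronger inhibition and higher numbers for weaker inhibition), gives > 5000 nM, which is a limit of the assay and not a number.
Compound 2, `CC1CCN(C2CCN(S(=O)(=O)c3ccc(C(C)(C)C)cc3)CC2)CC1`, in this assay gives > 5000 nM, also a limit.
Compound 3, `Cc1cc(C)c(S(=O)(=O)N2CCC(C3OCC(C)CO3)CC2)c(C)c1`, in this assay gives > 5000 nM, again a limit.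

All three measured compounds sit at the limit of > 5000 nM in this assay, at which 3 of the 3 values shown sit. Because the limit of > 5000 nM in this assay, at which 3 of the 3 values shown sit, is where every value shown stands, no ordering among them can be read, and compound 2 stands at that limit alongside the other two, with no sign that any of them harms the cells within the tested range.

Compound 4, `CC1CCN(C2CCN(S(=O)(=O)c3ccc(C#N)cc3)CC2)CC1`, has not yet been measured. It differs from compound 2 in a single place: cyano in place of tert-butyl on an aromatic carbon. Among the compounds with values here, no step between two measured compounds is available for this change, so the expectation rests only on the fact that every measured compound, with quite different groups on its aromatic ring, stayed at the limit. The step that the limit leaves unreadable from compound 2 to compound 4 is therefore expected to be none beyond the usual scatter. Compound 4 is expected to give about 10000 nM in this assay, within 4000 nM to 30000 nM, and the most likely outcome is once more a limit rather than a number.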

Compound 4, half-maximal inhibitory concentration: > 5000 nM
Compound 4 gave a limit, no number; the forecaster's own chance of this, stated with the estimate: 85%; the middle value does not contradict the limit.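

Compound 2 and compound 4 both stand at the limit of the assay, so the change from tert-butyl to cyano gives no step that can be read: the limit of > 5000 nM in this assay, at which 4 of the 4 values shown sit.

The compounds shown leave open whether any of them would harm the cells in this assay at concentrations beyond that limit, and whether this change would matter there.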